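The source may hold more compounds than are shown below. What is called first, only, known or untested is meant among the compounds shown, and "the series" means these compounds.

Measured in a functional assay on LS174T cells (Homo sapiens) for antiproliferative activity, with a stated time of 4 days; on this read-out higher numbers stand for weaker inhibition and lower numbers for stronger inhibition:
- compound 1, `CN(C)c1ccc(C#Cc2ccccc2F)cc1`: 39 nM
- compound 3, `CN(C)c1ccc(C#Cc2cccc(F)c2F)cc1`: 119 nM
- compound 2, `CN(C)c1ccc(C#Cc2ccc(F)cc2)cc1`: a limit only, > 3000 nM

Compound 1 and compound 3 share a core and differ by fluoro in place of hydrogen on an aromatic carbon; this change gives a 3.1-fold higher number from compound 1 to compound 3 (0.48 log units; beyond the scatter), a modest weakening. Compound 2 has the same atoms as compound 1 joined differently; the difference between the two cores is not broken down here. For compound 2 this assay gives only a limit, > 3000 nM, not a number.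

Compound 4, `CN(C)c1ccc(C#Cc2ccc(F)c(F)c2)cc1`, is not yet measured. It differs from compound 2 by fluoro in place of hydrogen on an aromatic carbon. The place is the same word for word as for the step from compound 1 to compound 3, so this is the same change, seen twice in the set.

Among the measured compounds shown here, compound 4 is expected to stay at or beyond the limit, because compound 2 already sits at the limit of > 3000 nM in this assay, at which 1 of the 3 values shown sits, and the one measured instance of this change weakened potency by a 3.1-fold higher number from compound 1 to compound 3 (0.48 log units; beyond the scatter). The expected step is a step that the limit leaves unreadable from compound 2 to compound 4. The estimate for compound 4 in this assay is 7000 nM, in the range 2500 nM to 25000 nM.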

Compound 4, half-maximal inhibitory concentration: > 3000 nM
Compound 4 was reported as a limit (the forecaster's own chance of this, stated with the estimate: 80%); the middle value lies beyond the limit too.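

Compound 2 and compound 4 both stand at a limit in this assay, so no new step can be read between them: the limit of > 3000 nM in this assay, at which 2 of the 4 values shown sit.

The compounds shown leave open how far fluoro in place of hydrogen on an aromatic carbon moves potency on the core of compound 2, and whether that shift matches the one readable instance of this change.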